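This account rests on a few compounds, and the source may have more. Where it says the series, first, only, none or still open, it means among the compounds named here.

Measured compounds:
compound 1, `Nc1ccccc1NC(=O)/C=C/c1ccc(COCNc2nc(Nc3cccc(Cl)c3)c3ncn(C4CCCC4)c3n2)cc1`, 9.19%
compound 2, `CC(C)n1cnc2c(Nc3cccc(Cl)c3)nc(NCOCc3ccc(C(=O)Nc4ccccc4N)cc3)nc21`, 63.4%
compound 3, `Nc1ccccc1NC(=O)c1ccc(COCNc2nc(Nc3ccccc3)c3ncn(C4CCCC4)c3n2)cc1`, 76.9%

In a functional assay on HCT-116 cells (Homo sapiens) for antiproliferative activity, read by CCK-8 assay, with a stated time of 72 h, tested at 8 uM (on this read-out higher numbers stand for a stronger effect at the one concentration tested and lower numbers for a weaker effect), compound 3 gives the highest of the three numbers, 76.9%. The nearest number is that of compound 2, which in this assay gives 63.4%, a gap beyond the scatter, and the furthest is that of compound 1, which gives 9.19%.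

Compound 4, `Nc1ccccc1NC(=O)c1ccc(COCNc2nc(Nc3cccc(Cl)c3)c3ncn(C4CCCC4)c3n2)cc1`, has not yet been measured. It differs from compound 3 in one place: chloro in place of hydrogen on an aromatic carbon. Going by the values given here, no step between two measured compounds isolates this change, so the direction is uncertain. A modest downward step in this assay is expected, a number 8.9 percentage points lower from compound 3 to compound 4 (within the scatter), though a step within the scatter would not surprise. Compound 4 is therefore estimated at 68%, between 48% and 85%.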

Compound 4, a percentage reported as inhibition, at one concentration (the size of the read-out at that concentration, not a potency): 40.6%
For compound 4 the middle estimate is 27.4 percentage points above the measured one; the measured number lies below the stated range.
By their numbers in this assay, from the lowest: compound 1; then compound 4; then compound 2; then compound 3.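

In this assay, going by these compounds alone, chloro in place of hydrogen on an aromatic carbon, phenyl to 3-chlorophenyl, proves costly, with a number 36.3 percentage points lower from compound 3 to compound 4 (beyond the scatter) as a large step and the first direct reading of this change. With 3-chlorophenyl held, cyclopentyl in place of isopropyl on an aromatic nitrogen gives a number 22.8 percentage points lower from compound 2 to compound 4 (beyond the scatter) as a modest step, and (2-aminophenyl)carbamoyl in place of 2-((2-aminophenyl)carbamoyl)ethenyl gives a number 31.4 percentage points higher from compound 1 to compound 4 (beyond the scatter) as a large one.

Going by these compounds, whether fluoro, bromo or methoxy at this place would give a similar loss stays open. Nothing at hand bears on why the number falls with this chloro.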